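Phenyl for dichlorophenyl on a cyanosulfanyl core

The compounds below may be only part of what the source reports. "The series", "measured", "known", "first", "only" and "open" are said of these compounds alone.

Compound 1 `O=Cc1c(-c2ccc(Cl)cc2Cl)nc2sc(Cc3ccc(Cl)cc3)nn12`: 82000 nM
Compound 2 `O=Cc1c(-c2ccccc2)nc2sc(Cc3ccc(Cl)cc3)nn12`: 20000 nM
Compound 3 `N#CSc1c(-c2ccc(Cl)cc2Cl)nc2sc(Cc3ccc(Cl)cc3)nn12`: 49000 nM

In a functional assay on L1210 cells (Mus musculus) for cytotoxicity, with a stated time of 48 h (a higher number here means a weaker inhibitor, a lower number a stronger inhibitor), compound 1 gives 82000 nM, compound 2 gives 20000 nM and compound 3 gives 49000 nM. Compound 4 `N#CSc1c(-c2ccccc2)nc2sc(Cc3ccc(Cl)cc3)nn12` has not been measured. The change from compound 3 to compound 4 is phenyl in place of 2,4-dichlorophenyl on an aromatic carbon, which gave a 4.1-fold lower number from compound 1 to compound 2 (0.61 log units; beyond the scatter) when made as phenyl in place of 2,4-dichlorophenyl on an aromatic carbon. The two cores differ by cyanosulfanyl in place of formyl on an aromatic carbon, a change that gave a 1.7-fold lower number from compound 1 to compound 3 (0.22 log units; within the scatter). Around the place of the change, the ring atom in compound 3 bears a cyanosulfanyl group where that in compound 1 bears a formyl group, so the two changes are of the same kind rather than the same. Compound 4 is expected to show a 4.1-fold lower number from compound 3 to compound 4 (0.61 log units; beyond the scatter) in this assay, resting on the earlier step and on compound 3 giving 49000 nM. Compound 4 is thus estimated at 12000 nM, between 5000 nM and 30000 nM.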

Compound 4, half-maximal inhibitory concentration: 24000 nM
Compound 4: the middle estimate sits 2.0-fold (0.30 log units) below what was measured; the range from low to high includes it.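

In this assay, phenyl in place of 2,4-dichlorophenyl gives a 2.0-fold lower number from compound 3 to compound 4 (0.31 log units; beyond the scatter), and this step agrees in direction with the one on the formyl core, while the two sizes cannot be told apart: the same change on two cores in this assay, a 4.1-fold lower number (0.61 log units; beyond the scatter) from compound 1 to compound 2 and a 2.0-fold lower number (0.31 log units; beyond the scatter) from compound 3 to compound 4, 2.0-fold (0.30 log units) apart, within the scatter of two such steps. Cyanosulfanyl in place of formyl, now read on the phenyl compounds, gives a 1.2-fold higher number from compound 2 to compound 4 (0.08 log units; within the scatter), and this exchange also reads alike on both cores: the same change on two cores in this assay, a 1.7-fold lower number (0.22 log units; within the scatter) from compound 1 to compound 3 and a 1.2-fold higher number (0.08 log units; within the scatter) from compound 2 to compound 4, 2.0-fold (0.30 log units) apart, within the scatter of two such steps. This shows that the phenyl change carried over between these two cores in this one cell assay, but it does not show that it would carry over to any other core.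

As far as these compounds go, it remains open whether the step would hold with a carboxylic acid or an amine at the place of the formyl and cyanosulfanyl groups. Also open, from the compounds shown here alone, is how a single chlorine or a methoxy group on the phenyl ring would compare.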